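Compound 4: a small extension of compound 3

The source may hold more compounds than are shown below. What is called first, only, known or untested is meant among the compounds shown, and "the series" means these compounds.

Values in a functional assay on MDA-MB-231 cells (Homo sapiens) for inhibition, read by MTT assay, with a stated time of 72 h; on this read-out higher numbers stand for weaker inhibition and lower numbers for stronger inhibition:
- compound 1 `Nc1ncnc2c1c(-c1cnc3[nH]ccc3c1)nn2CC(=O)NO`: > 150000 nM (a limit)
- compound 2 `Nc1ncnc2c1c(-c1cnc3[nH]ccc3c1)nn2CCCCCCCCC(=O)NO`: 11000 nM
- compound 3 `Nc1ncnc2c1c(-c1cnc3[nH]ccc3c1)nn2CCCCCC(=O)NO`: > 100000 nM (a limit)

Compound 3 has only a limit, > 100000 nM, and no exact number. Compound 4 `Nc1ncnc2c1c(-c1cnc3[nH]ccc3c1)nn2CCCCCCC(=O)NO` differs from it by (hydroxycarbamoyl)methyl in place of hydroxycarbamoyl on a saturated chain carbon, five bonds along the chain from an aromatic nitrogen. The most useful guide is an at least 9.0-fold higher number from compound 2 to compound 3 (0.95 log units; beyond the scatter), where hydroxycarbamoyl replaces 3-(hydroxycarbamoyl)propyl at that same place. The other step, a step that the two limits leave unreadable from compound 1 to compound 3, gives no size. Compound 4 makes a smaller change, in the opposite direction, so it should recover only part of that step. The expected change in this assay is an at least 2.2-fold lower number from compound 3 to compound 4 (0.34 log units; beyond the scatter), towards stronger inhibition. For compound 4 the estimated value is 45000 nM, with an expected range of 15000 nM to 130000 nM.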

Compound 4, half-maximal inhibitory concentration: 37700 nM
Estimate against measurement, compound 4: 1.2-fold (0.08 log units) above, within the range that was stated.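

In this assay, the swap of hydroxycarbamoyl for (hydroxycarbamoyl)methyl turns an open-ended reading into an exact one, with an at least 2.6-fold lower number from compound 3 to compound 4 (0.42 log units; beyond the scatter). That size rests on a limit: the limit of > 100000 nM in this assay, at which 1 of the 4 values shown sits. The exact value also places this chain length in the middle, with a 3.4-fold higher number from compound 2 to compound 4 (0.53 log units; beyond the scatter) and an at least 3.9-fold lower number from compound 1 to compound 4 (0.59 log units; beyond the scatter), so the number falls as the chain grows across the compounds that can be ordered. As far as these compounds go, whether a chain longer than that of compound 2 lowers the number further remains open. So does the effect of a carboxylic acid in place of the hydroxycarbamoyl end.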